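Aryl swap at the fused ring carbon: solubility notes

A few compounds are considered here, and "the series" means these few. Any claim that something is new, unique, unknown or untested is made for them only; others in the source may bear on it.

Compound 1 `CNC(=O)c1cc(C(=O)N[C@H]2[C@@H]3COC[C@@H]32)cc2c1OC[C@H]2c1cccc(OC)c1` — in a physicochemical assay for solubility (on this read-out lower numbers stand for lower solubility and higher numbers for higher solubility), compound 1 gives >= 186 ug/mL, which is a limit of the assay.
Compound 2 `CNC(=O)c1cc(C(=O)N[C@H]2C[C@@H]2C)cc2c1OC[C@@]2(C)c1ccccc1` — in this assay compound 2 gives 3 ug/mL.
Compound 3 `CNC(=O)c1cc(C(=O)NC2CC2)cc2c1OC[C@H]2c1cccc(OC)c1` — in this assay compound 3 gives >= 161 ug/mL, which is a limit of the assay.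

Compound 1 stands at the upper edge of what the numbers show: its value is a limit, not a read number. Two of the three values sit at limits the limit of >= 186 ug/mL in this assay, at which 1 of the 3 values shown sits, and (the limit of >= 161 ug/mL in this assay, at which 1 of the 3 values shown sits), and only compound 2 is a read number. Going by the values given here, the one step between measured compounds, a step that the two limits leave unreadable from compound 1 to compound 3, has both ends at limits and so gives no size; it concerns the amide-type nitrogen and not the position changed here.

Compound 4 `CNC(=O)c1cc(C(=O)N[C@H]2[C@@H]3COC[C@@H]32)cc2c1OC[C@H]2c1ccccc1C` differs from compound 1 by 2-methylphenyl in place of 3-methoxyphenyl on a saturated ring carbon. Among the compounds with values here, no measured step touches this position. Compound 2 carries a different aryl group but differs from compound 1 in more than one place, so its value alone says nothing about this change. With compound 1 already at a limit, any modest change may stay hidden; the step expected is an at least 1.6-fold lower number from compound 1 to compound 4 (0.22 log units; that floor lies within the scatter). Compound 4 is estimated at 110 ug/mL, with a range from 30 ug/mL to 200 ug/mL.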

Compound 4, solubility: >= 103 ug/mL
Compound 4 was reported as a limit; the forecaster's own chance of this, stated with the estimate: 40%; the middle value is on the limit's open side.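

In this assay compound 4 gives >= 103 ug/mL, which is a limit of the assay and not a read number. The value of compound 1 is also a limit, so no step can be read between compound 1 and compound 4. The compounds shown leave open the size and direction of any shift on placing 2-methylphenyl for 3-methoxyphenyl on this saturated ring carbon.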